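Trimming the sulfonyl side chain: compound 3 to compound 4

The compounds below may be only part of what the source reports. "The series", "measured", "known", "first", "only" and "open" are said of these compounds alone.

Measured in an ADME assay on the whole organism (Rattus norvegicus, strain Sprague-Dawley) for pharmacokinetics, at a dose of 2 mg/kg by the oral route (on this read-out higher numbers stand for higher exposure at the dose given and lower numbers for lower exposure), so far:
- compound 1 `CC1(C)CC(c2c[nH]c3c(C(N)=O)cc(-c4ccccc4)cc23)CCS1(=O)=O` gives 1430 ng.h/mL
- compound 2 `CC1(C)C[C@H](c2c[nH]c3c(C(N)=O)cc(-c4ccc(F)cc4)cc23)CCS1(=O)=O` gives 1960 ng.h/mL
- compound 3 `NC(=O)c1cc(-c2ccccc2)cc2c(C3CCN(S(=O)(=O)CCCN4CCCC4)CC3)c[nH]c12` gives 998 ng.h/mL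

Compound 3 lies within the usual scatter of both compound 1 and compound 2 in this assay so these three values cannot be told apart.

Compound 4 `CCS(=O)(=O)N1CCC(c2c[nH]c3c(C(N)=O)cc(-c4ccccc4)cc23)CC1` is compound 3 with a shorter chain on the sulfonyl sulfur, and the difference is hydrogen in place of (pyrrolidin-1-yl)methyl on a saturated chain carbon, two bonds along the chain from a sulfonyl sulfur on a saturated chain carbon, two bonds along the chain from a sulfonyl sulfur. Read one bond further out, this is 3-(pyrrolidin-1-yl)propyl to ethyl.

Within the data shown here, no measured pair isolates this change. Compound 1 (1430 ng.h/mL) and compound 2 (1960 ng.h/mL) also lack the pyrrolidinyl chain, but they differ from compound 3 elsewhere too, so they offer only a loose guide. A small upward move is expected, and the estimated 1.5-fold higher number from compound 3 to compound 4 (0.18 log units; within the scatter) stays within the scatter.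

Estimated for compound 4: 1500 ng.h/mL (expected range 600 ng.h/mL to 3600 ng.h/mL).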

Compound 4, area under the concentration-time curve: 1220 ng.h/mL
Estimate against measurement, compound 4: 1.2-fold (0.09 log units) above, within the range that was stated.
By their numbers in this assay, from the lowest: compounds 3, 4, 1 and 2 (each within the scatter of the next).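

Among these compounds, the step of a 1.2-fold higher number from compound 3 to compound 4 (0.09 log units; within the scatter) is the first single-place comparison in this assay, and it concerns the group on the sulfonyl sulfur. Exchanging 3-(pyrrolidin-1-yl)propyl for ethyl removes the pyrrolidine ring and its six-heavy-atom (pyrrolidin-1-yl)methyl section, yet compound 3 and compound 4 cannot be told apart on this read-out, so at this dose the chain's basic-free comparison gives no sign that exposure depends on that section. No supporting measurement is available to explain this result.

Open, on these data alone, is whether this holds for other groups at this place, such as a carboxylic acid or a primary amine at the end of the chain, or a longer unbranched alkyl chain. A single step within the scatter also cannot show how far this tolerance extends.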